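The compounds below may be only part of what the source reports. "The series", "measured", "known", "first", "only" and "open" are said of these compounds alone.

In a functional assay on U2OS cells for antagonist activity at C-X-C chemokine receptor type 3 (Homo sapiens), read by beta-arrestin recruitment (on this read-out lower numbers stand for stronger inhibition and higher numbers for weaker inhibition), compound 2 `Cc1ncc(-c2nc(C(F)(F)F)sc2N2CCN(C(=O)Cn3cnc4cccnc43)[C@H](C)C2)cn1` gives 168 nM, and compound 1 `COc1ncc(-c2nc(C(F)(F)F)sc2N2CCN(C(=O)Cn3cnc4cccnc43)[C@H](C)C2)cn1` gives 177 nM; the two are separated only by a 1.1-fold lower number from compound 1 to compound 2 (0.02 log units; within the scatter), which is within the scatter, so neither can be ranked ahead of the other. Compound 3 `COCCOc1ncc(-c2nc(C(F)(F)F)sc2N2CCN(C(=O)Cn3cnc4cccnc43)[C@H](C)C2)cn1` differs from compound 2 by 2-methoxyethoxy in place of methyl on an aromatic carbon, the substituent sitting on an aromatic carbon of a six-membered aromatic ring with 2 nitrogen, between two ring nitrogen atoms. For the measured compounds named here, the only measured step that bears on this position is a 1.1-fold lower number from compound 1 to compound 2 (0.02 log units; within the scatter), where methyl in place of methoxy left the number essentially unchanged. On that basis the longer 2-methoxyethoxy is expected to leave compound 3 close to compound 2 in this assay, with a step of about a 1.1-fold higher number from compound 2 to compound 3 (0.03 log units; within the scatter) that stays within the scatter. Compound 3 is therefore estimated at 180 nM, with a range from 80 nM to 400 nM.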

Compound 3, half-maximal inhibitory concentration: 324 nM
Beside the measured number, compound 3's estimate is 1.8-fold (0.26 log units) below it; the measured number falls inside the stated range.
By their numbers in this assay, from the lowest: compounds 2, 1 and 3 (each within the scatter of the next).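

Compound 3 extends what the earlier pair showed: in this assay this position accepts not only methyl and methoxy but also the longer 2-methoxyethoxy, with a 1.9-fold higher number from compound 2 to compound 3 (0.29 log units; within the scatter) against the methyl compound. Read as methoxymethyl in place of hydrogen on the chain carbon bound to the oxygen, the same change gives a 1.8-fold higher number from compound 1 to compound 3 (0.26 log units; within the scatter), so neither step allows compound 3 to be ranked apart from compound 2 or compound 1. No measurement at hand offers an explanation for these numbers.

On these data alone, it remains open whether the position would stay this undemanding with a group of another kind, such as an amine or a carboxylic acid at the end of the chain. A still longer ether chain, or a ring in that place, could also carry the numbers beyond the scatter.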